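The source may hold more compounds than are shown below. What is called first, only, known or untested is meant among the compounds shown, and "the series" means these compounds.

Among the compounds with values here, compound 2 `Cc1nn(-c2ncnc3nc[nH]c23)c2c1C(NC(=O)Cc1cccs1)CC(=O)N2` is one of two compounds measured in a functional assay on HEK293 cells for agonist activity at G-protein coupled receptor 39 (Homo sapiens), read by scintillation proximity assay and inositol phosphate accumulation, with a stated time of 75 min, in the presence of a further agent that is not named here; a higher number here means that more compound is needed for the effect, a lower number that less compound is needed. In this assay compound 2 gives 3 nM, and compound 1 `Cc1nn(-c2ncnc3nc[nH]c23)c2c1C(OCc1ccc(Cl)cc1Cl)CC(=O)N2` gives 4 nM; the step of a 1.3-fold lower number from compound 1 to compound 2 (0.12 log units; within the scatter) is within the scatter, so the two stand together, and compound 2 simply holds the smaller of the two numbers shown. Compound 3 `Cc1nn(-c2ncnc3nc[nH]c23)c2c1C(OCC(C)C)CC(=O)N2` has not been measured. It differs from compound 2 in one place: isobutoxy in place of (((thiophen-2-yl)methyl)carbonyl)amino on a saturated ring carbon. Within the data shown here, the only measured step, from compound 1 to compound 2, exchanged one ring-bearing group on that saturated ring carbon for another and moved the number only within the scatter. Among the measured compounds shown here, no step shows what happens when a ring at this position is given up for a short chain such as isobutoxy, so the scatter-sized step from compound 1 to compound 2 bears on it only loosely. A modest rise in this assay is expected for compound 3, with a step of a 3.3-fold higher number from compound 2 to compound 3 (0.52 log units; beyond the scatter) and a wide range. Compound 3 is estimated at 10 nM, between 3 nM and 40 nM.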

Compound 3, half-maximal effective concentration: 4 nM
Estimate against measurement, compound 3: 2.5-fold (0.40 log units) above, and the stated range covers the measured number.
By their numbers in this assay, from the lowest: compounds 2, 1 and 3 (each within the scatter of the next).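

In this assay, the exchange of (((thiophen-2-yl)methyl)carbonyl)amino for isobutoxy on the saturated ring carbon gives a 1.3-fold higher number from compound 2 to compound 3 (0.12 log units; within the scatter), so a group with no ring stands level with the ring-bearing group here, which the earlier pair, both carrying rings, could not show. With the ether oxygen kept, the exchange of 2,4-dichlorophenyl for isopropyl on the saturated chain carbon bound to that oxygen gives no change at the digits printed from compound 1 to compound 3 (within the scatter), so across these three compounds neither an aromatic ring nor the amide hydrogen of compound 2 is needed to keep the number in this range. Nothing at hand explains why these different groups give such closely matched numbers.

The compounds shown leave open how small or how large the group on this carbon can become, for instance a free hydroxyl, a primary amine, a carboxylic acid or a longer chain such as octyloxy. They also leave open whether a ring-free chain holds up when joined through an amide rather than an ether oxygen, as in an isobutyrylamino group.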